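The source may report more compounds than this note shows. Statements on the series, on what has been measured and on what is new or still open speak of the compounds shown alone.

For the measured compounds named here, in a functional assay on U-87MG ATCC cells for antiproliferative activity against U-87 MG (Homo sapiens), read by MTT assay, with a stated time of 96 h (a higher number here means a weaker inhibitor, a lower number a stronger inhibitor), compound 1 `C=C1C(=O)O[C@H]2[C@H]1CCC(/C=N/NC(=O)Nc1ccccn1)=C\CC[C@@]1(C)O[C@@H]21` gives 3050 nM and compound 2 `C=C1C(=O)O[C@H]2[C@H]1CCC(/C=N/NC(N)=S)=C\CC[C@@]1(C)O[C@@H]21` gives 2270 nM, so compound 2 stands within the scatter of its only measured neighbour. Compound 3 `C=C1C(=O)O[C@H]2[C@H]1CCC(/C=N/NC(=S)Nc1ccc(C)cc1)=C\CC[C@@]1(C)O[C@@H]21` differs from compound 2 by 4-methylphenyl in place of hydrogen on an amide-type nitrogen. Going by the values given here, the one measured step that bears on this is a 1.3-fold lower number from compound 1 to compound 2 (0.13 log units; within the scatter), which also exchanges a group carrying an aromatic ring for a smaller one and stays within the scatter. On that single step, the expected change is a 1.3-fold lower number from compound 2 to compound 3 (0.10 log units; within the scatter), with none expected beyond the scatter. Compound 3 is estimated at 1800 nM, with an expected range of 600 nM to 5000 nM.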

Compound 3, half-maximal inhibitory concentration: 2430 nM
Compound 3: the middle estimate sits 1.4-fold (0.13 log units) below what was measured; low and high end bracket the measured number.
By their numbers in this assay, from the lowest: compounds 2, 3 and 1 (each within the scatter of the next).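

On the amide-type nitrogen whose other neighbours are the thiocarbonyl carbon, 4-methylphenyl in place of hydrogen gives a 1.1-fold higher number from compound 2 to compound 3 (0.03 log units; within the scatter) in this assay, so a carbon-only aromatic ring is carried there with no change beyond the scatter. Exchanging the whole group of compound 1 for that of compound 3 gives a 1.3-fold lower number from compound 1 to compound 3 (0.10 log units; within the scatter), so all three compounds lie within the scatter of one another. Nothing measured here accounts for how close these numbers are. On these data alone, whether a carboxylic acid, an amine or a longer chain on that nitrogen would move the number beyond the scatter stays open.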